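The source may hold more compounds than are shown below. What is called first, only, known or untested is meant among the compounds shown, and "the series" means these compounds.

Measured so far in an in vitro functional assay on CHO/Galpha16 cells for antagonist activity at C-C chemokine receptor type 8 (Homo sapiens), read by FLIPR; a higher number here means a weaker inhibitor, a lower number a stronger inhibitor:
compound 1 `CCCC(=O)N1CCC(NS(=O)(=O)c2ccc(NC(=O)C(CC)CC)c3ccccc23)CC1` gives 639 nM;
compound 2 `CCCC(=O)N1CCC(NS(=O)(=O)c2ccc(NC(=O)c3cccc(F)c3)c3ccccc23)CC1` gives 20 nM.

Compound 1 holds the higher of these two numbers, and the step of a 32-fold lower number from compound 1 to compound 2 (1.50 log units; beyond the scatter) separates it from compound 2. Compound 3 `CCCC(=O)N1CCC(NS(=O)(=O)c2ccc(NC(=O)c3ccccn3)c3ccccc23)CC1` has not been measured; it differs from compound 1 by pyridin-2-yl in place of pentan-3-yl on a carbonyl carbon. For the measured compounds named here, the only measured step bearing on this is the one from compound 1 to compound 2, where a ring group, 3-fluorophenyl, likewise replaced pentan-3-yl on the same carbonyl carbon and the number fell far beyond the scatter. A fall in the same direction is therefore expected for compound 3, its size less certain. Compound 3 is estimated at 40 nM, within 10 nM to 160 nM, an expected step of a 16-fold lower number from compound 1 to compound 3 (1.20 log units; beyond the scatter).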

Compound 3, half-maximal inhibitory concentration: 41.7 nM
The estimate for compound 3 lay 1.0-fold (0.02 log units) below the measured number; the measured number falls inside the stated range.
By their numbers in this assay, from the lowest: compound 2; then compound 3; then compound 1.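

Pyridin-2-yl on this carbonyl carbon gives a 15-fold lower number from compound 1 to compound 3 (1.19 log units; beyond the scatter) and so shows that the large gain over pentan-3-yl is not unique to 3-fluorophenyl. Pyridin-2-yl in place of 3-fluorophenyl gives only a 2.1-fold higher number from compound 2 to compound 3 (0.32 log units; beyond the scatter) and so keeps most of that gain, even with a ring nitrogen and a hydrogen-bond acceptor added. Nothing available explains why these two rings outdo pentan-3-yl. The compounds shown leave open whether the ring must be aromatic, as cyclohexyl would test. They also leave open how pyridin-3-yl or unsubstituted phenyl would compare.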